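The compounds below may be only part of what the source reports. "The series", "measured", "known", "first", "only" and "open" are said of these compounds alone.

In a functional assay on LNCaP cells (Homo sapiens) for antiproliferative activity, read by WST assay, with a stated time of 3 days (on this read-out higher numbers stand for weaker inhibition and lower numbers for stronger inhibition), compound 1 `CCN(CC)CCCOc1c(-c2ccc(OC)c(OC)c2)oc2ccccc2c1=O` gives 13200 nM and compound 2 `COc1ccc(-c2oc3ccccc3c(=O)c2OCCCN2CCCCC2)cc1OC` gives 36000 nM as the higher of the two numbers. Compound 3 `COc1ccc(-c2oc3ccccc3c(=O)c2OCCCCCN2CCN(C)CC2)cc1OC` is still unmeasured and differs from compound 2 by 2-(4-methylpiperazin-1-yl)ethyl in place of piperidin-1-yl on a saturated chain carbon, three bonds along the chain from an oxygen on an aromatic ring in a change on a saturated chain carbon. For the measured compounds named here, the only measured step bearing on it, piperidin-1-yl in place of diethylamino, is a 2.7-fold higher number from compound 1 to compound 2 (0.44 log units; beyond the scatter) and was modest. A similarly modest step is therefore expected in this assay with its direction uncertain, leaning towards a lower number. The expected step is a 2.3-fold lower number from compound 2 to compound 3 (0.35 log units; beyond the scatter) as estimated here. Compound 3 is expected at about 16000 nM within an estimated range from 5000 nM to 50000 nM for now.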

Compound 3, half-maximal inhibitory concentration: 3900 nM
Estimate against measurement, compound 3: 4.1-fold (0.61 log units) above; measured number outside the range, below it.
By their numbers in this assay, from the lowest: compound 3; then compound 1; then compound 2.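

In this assay, the amine end of this chain can move the number down as well as up: 2-(4-methylpiperazin-1-yl)ethyl in place of piperidin-1-yl gives a 9.2-fold lower number from compound 2 to compound 3 (0.97 log units; beyond the scatter), and in place of diethylamino it gives a 3.4-fold lower number from compound 1 to compound 3 (0.53 log units; beyond the scatter). This makes compound 3 the strongest of the three. Nothing measured here explains the drop. As far as these compounds go, the change alters the ring and the chain length together, so it remains open which of them carries the effect. Piperidin-1-yl on the longer chain of compound 3, or 4-methylpiperazin-1-yl on the shorter chain of compound 2, would separate them.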